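Fluoro in Place of Hydrogen on the Anilino Ring

The source may report more compounds than this note shows. Statements on the series, on what has been measured and on what is new or still open speak of the compounds shown alone.

Compound 1 `NC(=O)Cn1ccc2cc(-c3ccc4oc(NC5CCCCC5)nc4c3)ccc21`: 214 nM
Compound 2 `Cn1ccc2cc(-c3ccc4oc(Nc5ccccc5)nc4c3)ccc21`: 48 nM

In an assay on HEK293 cells for inhibition of Fatty-acid amide hydrolase 1 (Homo sapiens), read by fluorescence (a lower number here means a stronger inhibitor, a higher number a weaker inhibitor), compound 2 gives 48 nM, the lowest of the two numbers, while compound 1 gives 214 nM, a gap beyond the scatter. Compound 3 `Cn1ccc2cc(-c3ccc4oc(Nc5ccc(F)cc5)nc4c3)ccc21` differs from compound 2 by fluoro in place of hydrogen on an aromatic carbon, on an aromatic carbon of a six-membered aromatic ring of carbon only, para to a large group; anilino becomes (4-fluorophenyl)amino. For the measured compounds named here, no pair of measured compounds shows what this change does, so the expected step of a 1.1-fold lower number from compound 2 to compound 3 (0.03 log units; within the scatter) is none beyond the scatter. Compound 3 is therefore estimated at 45 nM, between 15 nM and 135 nM.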

Compound 3, half-maximal inhibitory concentration: 99 nM
Compound 3: middle estimate off by 2.2-fold (0.34 log units), on the low side, within the range that was stated.
By their numbers in this assay, from the lowest: compound 2; then compound 3; then compound 1.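

At this place on the six-membered aromatic ring, para to a large group, fluoro in place of hydrogen gives a 2.1-fold higher number from compound 2 to compound 3 (0.31 log units; beyond the scatter) in this assay. For the compounds shown here, this is the first step read on this ring, and it shows that a single fluorine atom here moves the number modestly but beyond the scatter, towards a weaker inhibitor. Nothing at hand explains this step. On these data alone, whether chloro, methoxy or an amine at the same place would move the number in the same direction stays open, as does whether fluoro on another carbon of this ring would give a step of similar size.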